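A few compounds are considered here, and "the series" means these few. Any claim that something is new, unique, unknown or untested is made for them only; others in the source may bear on it.

In an assay on isolated protein for binding affinity to corticotropin-releasing factor receptor 1 (Homo sapiens) (a higher number here means a weaker inhibitor, a lower number a stronger inhibitor), compound 1 `CCN(CC)c1cc(C)nc(N(CC)c2c(Cl)cc(OC)cc2OC)n1` gives 10 nM and compound 2 `CCN(CC)c1cc(C)nc(N(CC)c2c(Br)cc(Br)cc2OC)n1` gives 31 nM. Compound 3 `CCN(c1nc(C)cc(C)n1)c1ccc(N(C)C)cc1C(F)(F)F` stands at the highest of the three numbers, giving 68 nM in this assay; its gap to compound 2 and its wider gap to compound 1 both lie beyond the usual scatter. Compound 4 `CCN(CC)c1cc(C)nc(N(CC)c2ccc(N(C)C)cc2C(F)(F)F)n1` differs from compound 3 in one place: diethylamino in place of methyl on an aromatic carbon. Compound 1 and compound 2 both carry a diethylamino group at that position and show lower numbers than compound 3, though they differ from it elsewhere too. On that basis compound 4 is expected to shift by a 2.7-fold lower number from compound 3 to compound 4 (0.43 log units; beyond the scatter) in this assay, a drop in the number beyond the scatter. Compound 4 is therefore estimated at 25 nM, within a range from 8 nM to 80 nM.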

Compound 4, inhibition constant: 11 nM
Compound 4: the middle estimate sits 2.3-fold (0.36 log units) above what was measured, and the stated range covers the measured number.
By their numbers in this assay, from the lowest: compounds 1 and 4 (each within the scatter of the next); then compound 2; then compound 3.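

In this assay, the position next to the ring nitrogen responds clearly to this change: diethylamino in place of methyl gives a 6.2-fold lower number from compound 3 to compound 4 (0.79 log units; beyond the scatter). Earlier compounds carried diethylamino there only alongside differences elsewhere, whereas this pair isolates the swap in one place. Nothing measured here accounts for the size of the step.

Going by these compounds, it remains open how dipropylamino or a simple ethylamino would compare with diethylamino at this position. The compounds shown also leave open whether the same swap would have a similar effect with the other substituents of compound 1 or compound 2.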